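Shifting the Fluorine on the Aryl Group of Compound 3

A few compounds are considered here, and "the series" means these few. Any claim that something is new, unique, unknown or untested is made for them only; others in the source may bear on it.

Three compounds were measured in an assay on CHO cells for displacement of a labelled ligand from adenosine receptor A2b (Homo sapiens), read by scintillation counting, with a stated time of 75 min, in the presence of a further agent that is not named here; a higher number here means a weaker inhibitor, a lower number a stronger inhibitor:
compound 1 `CCCn1c(=O)[nH]c2nc(-c3ccc(S(=O)(=O)N4CCN(c5ccc(Cl)cc5F)CC4)cc3)[nH]c2c1=O` gives 1.91 nM
compound 2 `CCCn1c(=O)[nH]c2nc(-c3ccc(S(=O)(=O)N4CCN(Cc5cccc(C)c5)CC4)cc3)[nH]c2c1=O` gives 0.397 nM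
compound 3 `CCCn1c(=O)[nH]c2nc(-c3ccc(S(=O)(=O)N4CCN(c5ccccc5F)CC4)cc3)[nH]c2c1=O` gives 3.22 nM

Compound 3 stands at the highest of the three numbers, but its nearest neighbour is close: a 1.7-fold higher number from compound 1 to compound 3 (0.23 log units; within the scatter). Only the benzyl compound is clearly apart: an 8.1-fold higher number from compound 2 to compound 3 (0.91 log units; beyond the scatter).

Compound 4 `CCCn1c(=O)[nH]c2nc(-c3ccc(S(=O)(=O)N4CCN(c5cccc(F)c5)CC4)cc3)[nH]c2c1=O` differs from compound 3 by 3-fluorophenyl in place of 2-fluorophenyl on an amine nitrogen in a ring. Going by the values given here, no measured step moves a substituent from one position to another on this ring. The step of a 1.7-fold higher number from compound 1 to compound 3 (0.23 log units; within the scatter) removes a halogen altogether, and the step of a 4.8-fold lower number from compound 1 to compound 2 (0.68 log units; beyond the scatter) replaces the whole group, so neither speaks directly to this change. In this assay no step beyond the scatter is therefore expected: a 1.1-fold lower number from compound 3 to compound 4 (0.03 log units; within the scatter). The estimate for compound 4 is 3 nM, with a range from 1 nM to 10 nM.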

Compound 4, inhibition constant: 0.632 nM
For compound 4 the middle estimate is 4.7-fold (0.68 log units) above the measured one; the measured number lies below the stated range.
By their numbers in this assay, from the lowest: compounds 2 and 4 (each within the scatter of the next); then compounds 1 and 3 (each within the scatter of the next).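

In this assay, the place of the fluorine on the aryl group matters, even though 2-fluorophenyl and 3-fluorophenyl have the same atoms (a 5.1-fold lower number from compound 3 to compound 4 (0.71 log units; beyond the scatter)). The 3-fluorophenyl group also does better than the larger aryl group of compound 1 (a 3.0-fold lower number from compound 1 to compound 4 (0.48 log units; beyond the scatter)), while compound 4 cannot be told apart from the benzyl compound (a 1.6-fold higher number from compound 2 to compound 4 (0.20 log units; within the scatter)). Nothing given here explains why the shift has this effect. On these data alone, it remains open whether a methoxy group or a nitrile in place of this fluorine would give a similar number.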